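The source may report more compounds than this note shows. Statements on the series, on what has been measured and on what is new or still open speak of the compounds shown alone.

For the measured compounds named here, compound 2 `Cc1cc(-c2cccc(Cl)c2)cc(C)c1Nc1ccnc(Nc2ccc(C#N)cc2)n1` gives 2160 nM in an ADME assay on MT4 cells (Homo sapiens) for cytotoxicity, read by MTT assay, with a stated time of 4 days (on this read-out higher numbers stand for lower toxicity in this test and lower numbers for higher toxicity in this test), the highest of the two numbers recorded so far; the only neighbour is compound 1 `Cc1cc(-c2cccc(C#N)c2)cc(C)c1Nc1ccnc(Nc2ccc(C#N)cc2)n1`, which gives 920 nM in this assay, and the step of a 2.3-fold higher number from compound 1 to compound 2 (0.37 log units; beyond the scatter) separates them. Compound 3 `Cc1ccccc1-c1cc(C)c(Nc2ccnc(Nc3ccc(C#N)cc3)n2)c(C)c1` has not yet been measured in this assay. It differs from compound 2 by 2-methylphenyl in place of 3-chlorophenyl on an aromatic carbon. Going by the values given here, no measured step matches this change: the one step recorded, a 2.3-fold higher number from compound 1 to compound 2 (0.37 log units; beyond the scatter), concerns a different pair of groups at the same position, and it was modest. With nothing closer to lean on, the expectation for compound 3 is a step of a 1.2-fold higher number from compound 2 to compound 3 (0.06 log units; within the scatter) in this assay, of a size that may well stay within the scatter. Compound 3 is therefore estimated at 2500 nM in this assay, with a range from 1000 nM to 6000 nM.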

Compound 3, half-maximal cytotoxic concentration: 3820 nM
Beside the measured number, compound 3's estimate is 1.5-fold (0.18 log units) below it, and the stated range covers the measured number.
By their numbers in this assay, from the lowest: compound 1; then compounds 2 and 3 (each within the scatter of the next).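

In this assay, 2-methylphenyl in place of 3-chlorophenyl gives a 1.8-fold higher number from compound 2 to compound 3 (0.25 log units; within the scatter), so this change on the aromatic carbon leaves compound 2 and compound 3 indistinguishable in this test. The 3-cyanophenyl group stands apart from both: the change to 2-methylphenyl gives a 4.2-fold higher number from compound 1 to compound 3 (0.62 log units; beyond the scatter), and with a 2.3-fold higher number from compound 1 to compound 2 (0.37 log units; beyond the scatter) this leaves compound 1 with the lowest number of the three, the only separation at this position that lies beyond the scatter. No available evidence explains the difference between compound 1 and the other two.

The compounds shown leave open whether the group's identity or its place on the phenyl ring matters more, since 2-methylphenyl and 3-chlorophenyl differ in both, and 3-methylphenyl or 2-chlorophenyl would separate the two. They also leave open how an amine or a carboxylic acid on that ring would read in this test.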